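Swapping the base on a sugar-fused sulfone scaffold

The source may hold more compounds than are shown below. What is called first, only, known or untested is meant among the compounds shown, and "the series" means these compounds.

These compounds share a bicyclic sugar core carrying an amino-vinyl sulfone ring and were tested in a functional assay on MT4 cells (Homo sapiens) for cytotoxicity; a lower number here means that less compound is tolerated, a higher number that more compound is tolerated. Compound 3 `CCc1c[nH]c(=O)n([C@@H]2O[C@H](CO[Si](C)(C)C(C)(C)C)[C@@]3(OS(=O)(=O)C=C3N)[C@H]2O[Si](C)(C)C(C)(C)C)c1=O` gives 5500 nM, the lowest of the two numeric values. Compound 2 `CC(C)(C)[Si](C)(C)OC[C@H]1O[C@@H](n2ccc(=O)[nH]c2=O)[C@H](O[Si](C)(C)C(C)(C)C)C12OS(=O)(=O)C=C2N` gives a higher number, 15000 nM, beyond the usual scatter. Compound 1 `CC(=O)O[C@H]1[C@H](n2cc(C)c(=O)[nH]c2=O)O[C@H](COC(=O)c2ccccc2)[C@@]12OS(=O)(=O)C=C2N` reaches only the assay limit, > 200000 nM, which is a limit rather than a number (the limit of > 200000 nM in this assay, at which 1 of the 3 values shown sits). Compound 4 `CC(C)(C)[Si](C)(C)OC[C@H]1O[C@@H](n2ccc(N)nc2=O)[C@H](O[Si](C)(C)C(C)(C)C)[C@]12OS(=O)(=O)C=C2N` differs from compound 3 by a group of 8 heavy atoms (4 carbon, 3 nitrogen, 1 oxygen; one six-membered aromatic ring with 2 hetero atoms) in place of a group of 10 heavy atoms (6 carbon, 2 nitrogen, 2 oxygen; one six-membered aromatic ring with 2 hetero atoms), on a saturated ring carbon. For the measured compounds named here, with no measured pair of this kind, the direction is uncertain; a modest move toward a higher number is expected, since compound 2, with a related base, gives 15000 nM. For compound 4 in this assay the expected value is 12000 nM, with a range from 3000 nM to 50000 nM, a step of a 2.2-fold higher number from compound 3 to compound 4 (0.34 log units; beyond the scatter).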

Compound 4, half-maximal cytotoxic concentration: > 360000 nM
Compound 4: no number, only a limit (the forecaster's own chance of this, stated with the estimate: 15%); middle value at least 30-fold (1.47 log units) from the limit.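

For the compounds shown here, this is the first comparison between compounds that differ in one place: on the saturated ring carbon next to the ring oxygen, the group of 8 heavy atoms in place of the group of 10 heavy atoms gives an at least 65-fold higher number from compound 3 to compound 4 (1.81 log units; beyond the scatter). The group at this position can therefore shift tolerance in this assay by a large amount. The reading for compound 4 is a limit, not a number: the limit of > 360000 nM in this assay, at which 1 of the 4 values shown sits.

Still open, from the compounds shown here alone, is how far the true value of compound 4 lies beyond that limit. Also open, going by these compounds, is whether a carboxylic acid or a longer chain on this aromatic ring would shift the number in the same direction.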